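Cyano in Place of Bromo on the Sulfonyl Ring

The compounds below may be only part of what the source reports. "The series", "measured", "known", "first", "only" and "open" are said of these compounds alone.

Measured compounds:
compound 1, `CC1=NC(c2cn(S(=O)(=O)c3cccs3)c3ccc(C)cc23)CN1`: 22000 nM
compound 2, `CC1=NC(c2cn(S(=O)(=O)c3ccccc3Br)c3ccc(C)cc23)CN1`: 400 nM

In an assay on isolated protein for inhibition of kallikrein-7 (Mus musculus), read by fluorescence, with stated times of 10 min and 30 min (a higher number here means a weaker inhibitor, a lower number a stronger inhibitor), compound 1 gives 22000 nM, while compound 2 gives 400 nM, the lower of the two numbers. Among the measured compounds shown here, the single measured step, a 55-fold lower number from compound 1 to compound 2 (1.74 log units; beyond the scatter), changed the whole ring on the sulfonyl sulfur and so bears only loosely on a change within that ring. Compound 3, `CC1=NC(c2cn(S(=O)(=O)c3ccccc3C#N)c3ccc(C)cc23)CN1`, differs from compound 2 by cyano in place of bromo on an aromatic carbon. For the measured compounds named here, no measured step tests such a swap, so the expected step is a 2.0-fold higher number from compound 2 to compound 3 (0.30 log units; within the scatter), not clearly beyond the scatter. Compound 3 is estimated at 800 nM, ranging from 200 nM to 4000 nM.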

Compound 3, half-maximal inhibitory concentration: 11000 nM
Compound 3: the middle estimate sits 14-fold (1.14 log units) below what was measured; measured number above the stated range.
By their numbers in this assay, from the lowest: compound 2; then compounds 3 and 1 (each within the scatter of the next).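

In this assay, the step of a 28-fold higher number from compound 2 to compound 3 (1.44 log units; beyond the scatter) shows that this place on the sulfonyl ring responds strongly to the group it carries, and that cyano does not stand in for bromo there. The step of a 2.0-fold lower number from compound 1 to compound 3 (0.30 log units; within the scatter) lies within the scatter, so a substituted phenyl ring in place of thiophen-2-yl does not by itself give the low number of compound 2. Nothing at hand accounts for the gap between bromo and cyano. As far as these compounds go, whether chloro, methyl or methoxy at this place would match bromo or cyano stays open.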